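Methylsulfanyl for trifluoromethoxy on an aromatic carbon

The source may report more compounds than this note shows. Statements on the series, on what has been measured and on what is new or still open speak of the compounds shown alone.

Going by the values given here, in a functional assay on KB cells (Homo sapiens) for antiproliferative activity, read by sulforhodamine B assay, with a stated time of 3 days (on this read-out lower numbers stand for an effect already at smaller amounts and higher numbers for an effect only at larger amounts of compound), compound 2 `CCC1=C(O)c2c(oc(-c3ccc(OC(F)(F)F)cc3)cc2=O)C(CC)(CC)C1=O` gives 36.5 uM as the higher of the two numbers so far, against compound 1 `CCC1=C(O)c2c(oc(-c3ccc(C(C)C)cc3)cc2=O)C(CC)(CC)C1=O` with 8.13 uM as the lower. The change methylsulfanyl in place of trifluoromethoxy on an aromatic carbon leads to compound 3 `CCC1=C(O)c2c(oc(-c3ccc(SC)cc3)cc2=O)C(CC)(CC)C1=O` and puts methylsulfanyl in place of trifluoromethoxy on an aromatic carbon, para to a large group. Among the compounds with values here, the one measured step that bears on this is a 4.5-fold higher number from compound 1 to compound 2 (0.65 log units; beyond the scatter) and it is modest. A modest move to a lower number in this assay is expected, and the estimated step is a 2.3-fold lower number from compound 2 to compound 3 (0.36 log units; beyond the scatter) in that direction. For compound 3 the estimate is 16 uM with an expected range from 6 uM to 40 uM in this read-out.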

Compound 3, concentration for half-maximal effect: > 52.1 uM
Compound 3: a limit, no number (the forecaster's own chance of this, stated with the estimate: 3%); at least 3.2-fold (0.51 log units) between middle value and limit.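

In this assay compound 3 gives a limit and not a number: the limit of > 52.1 uM in this assay, at which 1 of the 3 values shown sits. The step to methylsulfanyl from trifluoromethoxy reads an at least 1.4-fold higher number from compound 2 to compound 3 (0.15 log units; that floor lies within the scatter), so these two groups cannot be ordered at this position. The step from isopropyl reads an at least 6.4-fold higher number from compound 1 to compound 3 (0.80 log units; beyond the scatter), so methylsulfanyl, like trifluoromethoxy, separates from isopropyl beyond the scatter.

From the compounds shown here alone, the actual number for compound 3 remains open, and with it the size of any gap to compound 2. Also open, going by these compounds, is how an amine, a carboxylic acid or a longer alkyl chain would read on this aromatic carbon.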